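Cyclopropyl in Place of Ethyl: An Expected Antiproliferative Outcome

This account rests on a few compounds, and the source may have more. Where it says the series, first, only, none or still open, it means among the compounds named here.

Compound 1 `CC[C@H](NC(=O)/C(C#N)=C/c1cccc(Br)n1)c1ccccc1` was tested in a functional assay on MM1 cells (Homo sapiens) for antiproliferative activity, read by MTT assay, with a stated time of 72 h (on this read-out lower numbers stand for stronger inhibition and higher numbers for weaker inhibition), where compound 1 gives 1100 nM. Compound 3 `C[C@H](NC(=O)/C(C#N)=C/c1cccc(Br)n1)c1ccccc1F` gives 1800 nM, which lies within the scatter of compound 1, while compound 2 `COc1cccc([C@H](C)NC(=O)/C(C#N)=C/c2cccc(Br)n2)c1` gives 2400 nM, a gap from compound 1 that is beyond the scatter. The only single-point step among these, a 1.3-fold lower number from compound 2 to compound 3 (0.12 log units; within the scatter), exchanges the aromatic substituent and leaves the alkyl group untouched. Compound 4 `N#C/C(=C\c1cccc(Br)n1)C(=O)N[C@H](c1ccccc1)C1CC1` differs from compound 1 by cyclopropyl in place of ethyl on a saturated chain carbon bound to an amide-type nitrogen and an aromatic carbon. Among the compounds with values here, no measured step touches this saturated carbon, so the expectation rests on the unchanged core, and compound 4 is expected to remain near compound 1, with a 1.1-fold lower number from compound 1 to compound 4 (0.04 log units; within the scatter). Compound 4 is therefore estimated at 1000 nM, within a range from 400 nM to 2500 nM.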

Compound 4, half-maximal inhibitory concentration: 1400 nM
The estimate for compound 4 lay 1.4-fold (0.15 log units) below the measured number; low and high end bracket the measured number.
By their numbers in this assay, from the lowest: compounds 1, 4, 3 and 2 (each within the scatter of the next, the first and the last beyond it).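

Cyclopropyl in place of ethyl on a saturated chain carbon bound to an amide-type nitrogen and an aromatic carbon gives a 1.3-fold higher number from compound 1 to compound 4 (0.10 log units; within the scatter) in this assay and so leaves the number within the scatter. Within the data shown here, this is the first reading at this carbon, since the earlier step changed only the aromatic substituent, and here the open ethyl chain and the three-membered ring cannot be told apart. Nothing available explains this outcome. From the compounds shown here alone, whether a longer chain, an amine or a carboxylic acid at this carbon would also stay within the scatter of compound 1 remains open.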